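The source may hold more compounds than are shown below. What is called first, only, known or untested is meant among the compounds shown, and "the series" means these compounds.

Measured so far:
compound 1 `Cc1cc2c(c(N)nn2C)c(N2CCCCC2)n1`: -152%
compound 2 `COCCNc1nc(C)cc2c1c(N)nn2C`: -10%

Both numbers come from an assay on isolated protein for inhibition of protein kinase C zeta type (Homo sapiens), read by mobility shift assay, tested at 30 uM; on this read-out higher numbers stand for more inhibition at the one concentration tested (going by the name of the read-out) and lower numbers for less inhibition. Going by the values given here, compound 2 stands highest of the two, compound 1 far below it; the one measured step is a number 142 percentage points higher from compound 1 to compound 2 (beyond the scatter), a large rise. Compound 3 `Cc1cc2c(cn1)c(N)nn2C` is the next case: hydrogen in place of (2-methoxyethyl)amino on an aromatic carbon. Among the compounds with values here, the only step that bears on it exchanged one substituent for another at that carbon rather than removing it, so its guidance is loose. The expected step is a number 8 percentage points higher from compound 2 to compound 3 (within the scatter), within the scatter. For compound 3 the estimate in this assay is -2%, range -40% to 25%.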

Compound 3, a percentage reported as inhibition, at one concentration (the size of the read-out at that concentration, not a potency): -59%
Estimate against measurement, compound 3: 57 percentage points above; the whole stated range lies above it.
By their numbers in this assay, from the lowest: compound 1; then compound 3; then compound 2.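

Hydrogen on this aromatic carbon gives the series its first reference point in this assay and the step is a number 49 percentage points lower from compound 2 to compound 3 (beyond the scatter) with the loss of (2-methoxyethyl)amino, but a number 93 percentage points higher from compound 1 to compound 3 (beyond the scatter) with the loss of piperidin-1-yl. Measured against hydrogen, the two groups thus move the number in opposite directions, so the outcome at this position depends on which group sits there. No evidence on hand accounts for either step.

Still open, from the compounds shown here alone, is whether a shorter chain, such as methylamino, or a plain amine would stand above compound 2. Also open, going by these compounds, is how a morpholine ring would compare with piperidin-1-yl at this carbon.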